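This account rests on a few compounds, and the source may have more. Where it says the series, first, only, none or still open, it means among the compounds named here.

Measured in an assay on membranes from HeLa cells for displacement of a labelled ligand from adenosine receptor A3 (Homo sapiens), read by scintillation counting, with a stated time of 180 min, tested at 1 uM; on this read-out higher numbers stand for more inhibition at the one concentration tested (going by the name of the read-out) and lower numbers for less inhibition:
compound 1 `CC1=C(C(=O)OCC(C)C)C(c2ccco2)NC(=O)N1C` gives 23%
compound 2 `CC1=C(C(N)=O)C(c2ccoc2)NC(=O)N1` gives 2%
compound 3 `CC1=C(C(N)=O)C(c2ccsc2)NC(=O)N1` gives 1%

Compound 3 has the lowest number of the three, but the step of a number 1 percentage points lower from compound 2 to compound 3 (within the scatter) is within the scatter, so compound 2 and compound 3 cannot be ranked; only compound 1 stands clearly higher.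

Compound 4 `CC1=C(C(=O)OC2CCCC2)C(c2ccsc2)NC(=O)N1` differs from compound 3 by cyclopentyloxy in place of amino on a carbonyl carbon. Going by the values given here, no measured step isolates this change. Among the compounds with values here, the one step known, a number 1 percentage points lower from compound 2 to compound 3 (within the scatter), concerns a different position and does not bear on it. Compound 1 carries an ester instead of the amide, yet also differs from compound 3 elsewhere, so its higher number is only a loose pointer. A rise in this assay is nevertheless expected for compound 4, of about a number 14 percentage points higher from compound 3 to compound 4 (beyond the scatter). The estimate for compound 4 is 15%, ranging from 0% to 35%.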

Compound 4, a percentage reported as inhibition, at one concentration (the size of the read-out at that concentration, not a potency): 5%
The estimate for compound 4 lay 10 percentage points above the measured number; low and high end bracket the measured number.
By their numbers in this assay, from the lowest: compounds 3, 2 and 4 (each within the scatter of the next); then compound 1.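

In this assay, the carbonyl carbon whose other neighbour is the double-bonded ring carbon now has its first isolated change, cyclopentyloxy in place of amino, with a number 4 percentage points higher from compound 3 to compound 4 (within the scatter). Exchanging the amide for this ester thus adds a five-membered carbon ring and removes the hydrogen-bond donor of amino without separating compound 4 from compound 3 on this read-out. No available evidence bears on this result.

Still open, on these data alone, is whether dimethylamino, or the hydroxyl of a carboxylic acid, on this carbonyl carbon would give a reading beyond the scatter. Also open, as far as these compounds go, is whether cyclopentyloxy gives the same outcome with furan-3-yl on the saturated ring carbon.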